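Swapping a Cyclopentylamino Urea for a Morpholine Amide

This account rests on a few compounds, and the source may have more. Where it says the series, first, only, none or still open, it means among the compounds named here.

Of the compounds shown here, three built on one shared core have been tested in a functional assay on MDA-MB-231 cells (Homo sapiens) for antiproliferative activity, read by MTT assay, with a stated time of 72 h; a lower number here means a stronger inhibitor, a higher number a weaker inhibitor. Compound 1 `O=C(Nc1ccc(-c2noc(-c3cccc(NS(=O)(=O)c4ccc(C(F)(F)F)cc4)c3)n2)c(Cl)c1)c1cccnc1` gives only the limit of that assay, > 10000 nM. Compound 2 `CCN(CC)C(=O)Nc1ccc(S(=O)(=O)Nc2cccc(-c3nc(-c4ccc(NC(=O)c5cccnc5)cc4Cl)no3)c2)cc1` gives a number in this assay, 8700 nM. Compound 3 `O=C(Nc1ccc(S(=O)(=O)Nc2cccc(-c3nc(-c4ccc(NC(=O)c5cccnc5)cc4Cl)no3)c2)cc1)NC1CCCC1` again gives only the limit, > 10000 nM. Compound 3 thus stands at the top edge of the measured range. The step from compound 2 to compound 3 is an at least 1.1-fold higher number from compound 2 to compound 3 (0.06 log units; that floor lies within the scatter), and from compound 1 to compound 3 it is a step that the two limits leave unreadable from compound 1 to compound 3. From compound 1 to compound 2 the step is an at least 1.1-fold lower number from compound 1 to compound 2 (0.06 log units; that floor lies within the scatter). The feature the limit of > 10000 nM in this assay, at which 2 of the 3 values shown sit, shows how little the numbers move across this small group.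

Compound 4 `O=C(Nc1ccc(-c2noc(-c3cccc(NS(=O)(=O)c4ccc(NC(=O)N5CCOCC5)cc4)c3)n2)c(Cl)c1)c1cccnc1` differs from compound 3 in one place: morpholin-4-yl in place of cyclopentylamino on a carbonyl carbon. The measured steps that bear on it are those that also alter the group on the carbonyl carbon, all three of which are either unreadable or sit within the scatter. No step beyond the scatter is therefore expected in this assay. Compound 4 is expected to give 10000 nM, with a likely range from 6000 nM to 20000 nM. That estimate means an expected step of a number no higher from compound 3 to compound 4 (the limit leaves the size open).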

Compound 4, half-maximal inhibitory concentration: > 10000 nM
Compound 4 ended at the assay's limit (the forecaster's own chance of this, stated with the estimate: 60%); the middle value sits exactly at the limit.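

In this assay, morpholin-4-yl in place of diethylamino on the carbonyl carbon gives an at least 1.1-fold higher number from compound 2 to compound 4 (0.06 log units; that floor lies within the scatter), so this change shows no real shift in activity. The steps that link the new compound to compound 1 and compound 3 cannot be read, as each joins two limits of the assay. Replacing cyclopentylamino, with its hydrogen-bond donor, by morpholin-4-yl, with its hydrogen-bond acceptor and no donor, therefore brings no readable gain at this carbonyl carbon, and the series has moved further towards a floor of the assay rather than a spread of numbers: the limit of > 10000 nM in this assay, at which 3 of the 4 values shown sit.

Among these compounds, compound 2 remains the only compound with a number, 8700 nM. On these data alone, how far the others lie past the limit stays unknown, and so does any true ranking among them. As far as these compounds go, it also remains open whether another group on this carbonyl carbon, such as dimethylamino, dipropylamino or piperazin-1-yl, would give a step beyond the scatter in this assay.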